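Removing one methoxy group across two matched pairs

A few compounds are considered here, and "the series" means these few. Any claim that something is new, unique, unknown or untested is made for them only; others in the source may bear on it.

Compound 1 `COc1cc(-c2cc(/C=C/C(=O)c3ccc(N)cc3)[nH]n2)cc(OC)c1OC` and compound 2 `COc1ccc(-c2cc(/C=C/C(=O)c3ccc(N)cc3)[nH]n2)cc1OC` differ by a single change, (hydrogen in place of methoxy on an aromatic carbon). In a functional assay on SK-MEL-2 cells (Homo sapiens) for cytotoxicity, read by sulforhodamine B assay, with a stated time of 48 h, tested at 100 uM (on this read-out lower numbers stand for a stronger effect and higher numbers for a weaker effect at the one concentration tested), compound 1 gives -85%, and compound 2 gives -86%; the step is a number 1 percentage points lower from compound 1 to compound 2 (within the scatter). Compound 3 `COc1cc(C(=O)/C=C/c2cc(-c3cc(OC)c(OC)c(OC)c3)n[nH]2)cc(OC)c1OC` is built on another core; the difference between the two cores is not broken down here. In this assay compound 3 gives -96%. Compound 4 `COc1ccc(-c2cc(/C=C/C(=O)c3cc(OC)c(OC)c(OC)c3)[nH]n2)cc1OC` is not yet measured; relative to compound 3 it carries the same change as in the first pair, (hydrogen in place of methoxy on an aromatic carbon), at a place described in the same words. Since the step in the first pair lay within the scatter, a comparably small step is expected here, a number 2 percentage points higher from compound 3 to compound 4 (within the scatter), resting on a number 1 percentage points lower from compound 1 to compound 2 (within the scatter). Compound 4 is accordingly estimated at -94% in this assay, with the expected range running from -104% to -82%.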

Compound 4, a percentage reported as activity, at one concentration (the size of the read-out at that concentration, not a potency): -92%
For compound 4 the middle estimate is 2 percentage points below the measured one; the measured number falls inside the stated range.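

In this assay, hydrogen in place of methoxy on the core of compound 3 gives a number 4 percentage points higher from compound 3 to compound 4 (within the scatter), a step that stays within the scatter, as it did on the core of compound 1. Set side by side, the two steps do not differ: the same change on two cores in this assay, a number 1 percentage points lower (within the scatter) from compound 1 to compound 2 and a number 4 percentage points higher (within the scatter) from compound 3 to compound 4, 5 percentage points apart, within the scatter of two such steps. On these two cores the change carries over without a readable effect, but this rests on two pairs at one concentration, which gives no potency and no rule for any other core.

The compounds shown leave open what a carboxylic acid, a hydroxyl or an ethoxy chain would do in place of this methoxy. Also open, from the compounds shown here alone, is whether the two steps would still agree at other concentrations.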